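Trading 3-fluoro-4-methoxyphenyl for 1-methyl-1H-indol-5-yl

This account rests on a few compounds, and the source may have more. Where it says the series, first, only, none or still open, it means among the compounds named here.

Compound 2 `COc1ccc(-c2cc3nccc(-c4cc(OC)c(OC)c(OC)c4)n3n2)cc1F` gives 236 nM in a functional assay on HeLa cells (Homo sapiens) for inhibition, read by CCK-8 assay, with a stated time of 48 h (on this read-out lower numbers stand for stronger inhibition and higher numbers for weaker inhibition), the lowest of the two numbers recorded. Its nearest neighbour is compound 3 `COc1cc(-c2ccnc3cc(-c4ccc(-c5cnn(C)c5)cc4)nn23)cc(OC)c1OC`, which gives 1830 nM in this assay. Compound 1 `COc1ccc(-c2cc3nccc(-c4cc(OC)c(OC)c(OC)c4)n3n2)cc1[N+](=O)[O-]` returns only the assay limit of > 10000 nM. Going by the values given here, the one single-point step recorded, an at least 42-fold lower number from compound 1 to compound 2 (1.62 log units; beyond the scatter), concerns a small substituent on the same six-membered ring. Compound 4 `COc1cc(-c2ccnc3cc(-c4ccc5c(ccn5C)c4)nn23)cc(OC)c1OC` differs from compound 2 by 1-methyl-1H-indol-5-yl in place of 3-fluoro-4-methoxyphenyl on an aromatic carbon, a change of a different kind, which that step does not cover. Compound 3, carrying a different aryl group, shows a higher number than compound 2, and a weakening of similar size is expected here. The expected step is a 5.1-fold higher number from compound 2 to compound 4 (0.71 log units; beyond the scatter). Compound 4 is therefore estimated at 1200 nM, between 350 nM and 4500 nM.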

Compound 4, half-maximal inhibitory concentration: 19 nM
The estimate for compound 4 lay 63-fold (1.80 log units) above the measured number, and the stated range ends above it.
By their numbers in this assay, from the lowest: compound 4; then compound 2; then compound 3. At a limit, above all of these: compound 1.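

At this aromatic carbon of the five-membered ring, 1-methyl-1H-indol-5-yl outperforms 3-fluoro-4-methoxyphenyl in this assay, with a 12-fold lower number from compound 2 to compound 4 (1.09 log units; beyond the scatter) and a clear gain in inhibition. Exchanging the aryl group here therefore need not weaken inhibition: compound 3 gives 1830 nM and compound 4 gives 19 nM, so the outcome depends on which aryl group enters. Nothing measured here explains this gain.

Still open, on these data alone, is whether the methyl on the indole nitrogen matters. An indole bearing hydrogen or a longer ethyl chain on that nitrogen would test this.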